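Lengthening the hydroxycarbamoyl chain: compound 3 to compound 4

A few compounds are considered here, and "the series" means these few. Any claim that something is new, unique, unknown or untested is made for them only; others in the source may bear on it.

The compounds share one core and differ only in the chain ending in hydroxycarbamoyl. In a functional assay on HCT-116 cells (Homo sapiens) for antiproliferative activity, read by sulforhodamine B assay, with a stated time of 72 h (a higher number here means a weaker inhibitor, a lower number a stronger inhibitor), compound 1 `Cn1cc(-c2ccc(=O)n(CCOc3ccnc4cc(OCCCC(=O)NO)ccc34)n2)cn1` gives > 10000 nM, which is a limit and not a number. Compound 2 `Cn1cc(-c2ccc(=O)n(CCOc3ccnc4cc(OCCCCC(=O)NO)ccc34)n2)cn1` gives > 10000 nM, also a limit. Compound 3 `Cn1cc(-c2ccc(=O)n(CCOc3ccnc4cc(OCCCCCC(=O)NO)ccc34)n2)cn1` gives > 10000 nM, again a limit, so it has no numerical position in the series. All three results stand at the same ceiling: the limit of > 10000 nM in this assay, at which 3 of the 3 values shown sit.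

Compound 4 `Cn1cc(-c2ccc(=O)n(CCOc3ccnc4cc(OCCCCCCC(=O)NO)ccc34)n2)cn1` extends the chain once more: (hydroxycarbamoyl)methyl in place of hydroxycarbamoyl on a saturated chain carbon, five bonds along the chain from an oxygen on an aromatic ring. The change is (hydroxycarbamoyl)methyl in place of hydroxycarbamoyl on a saturated chain carbon, five bonds along the chain from an oxygen on an aromatic ring.

The closest precedents are a step that the two limits leave unreadable from compound 1 to compound 2 and a step that the two limits leave unreadable from compound 2 to compound 3, with the longer jump being a step that the two limits leave unreadable from compound 1 to compound 3. None of these has a readable size, so they supply neither a trend nor a direction. No step beyond the scatter is therefore expected in this assay, and a further limit is the most likely report. The expected step is a number no higher from compound 3 to compound 4 (the limit leaves the size open). For compound 4 the estimated value is 10000 nM, with an expected range of 3000 nM to 30000 nM.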

Compound 4, half-maximal inhibitory concentration: > 10000 nM
Compound 4: no number, only a limit; the forecaster's own chance of this, stated with the estimate: 65%; the middle value sits exactly at the limit.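

Compound 4 returns a limit and not a number, so no new step can be read, and its steps from compound 1, compound 2 and compound 3 all stay unreadable: the limit of > 10000 nM in this assay, at which 4 of the 4 values shown sit.

Whether the length of the hydroxycarbamoyl chain changes potency at all in this assay remains open, as does any order among these four compounds.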